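Oxime in place of ketone, then chloro for methoxy

The compounds below may be only part of what the source reports. "The series", "measured", "known", "first", "only" and "open" are said of these compounds alone.

Of the compounds shown here, three from this series have been tested in a functional assay on PANC-1 cells (Homo sapiens) for inhibition, read by MTT assay, with a stated time of 48 h; a higher number here means a weaker inhibitor, a lower number a stronger inhibitor. Compound 1, `COc1ccc(C(=O)CSc2nc3c([nH]2)c(=O)n(C)c(=O)n3C)cc1`, gives 6400 nM. Compound 2, `Cn1c(=O)c2[nH]c(SCC(=O)c3ccc(Cl)cc3)nc2n(C)c1=O`, gives 7200 nM. The change between them is chloro in place of methoxy on an aromatic carbon, and it produced a 1.1-fold higher number from compound 1 to compound 2 (0.05 log units; within the scatter), so the two ketones sit together within the scatter of the method.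

Compound 3, `COc1ccc(/C(CSc2nc3c([nH]2)c(=O)n(C)c(=O)n3C)=N\O)cc1`, gives 910 nM in this assay. It carries the same methoxyphenyl group as compound 1, but the difference between the two cores is not broken down here. What the values show is that compound 3 has the lowest number of the three, and its gaps to compound 1 and to compound 2 both lie beyond the scatter, so among these three it is the strongest inhibitor.

Compound 4, `Cn1c(=O)c2[nH]c(SC/C(=N/O)c3ccc(Cl)cc3)nc2n(C)c1=O`, has not yet been measured. It differs from compound 3 by chloro in place of methoxy on an aromatic carbon. This is the same change, at the same place, that separates compound 1 from compound 2. Since that earlier change gave a 1.1-fold higher number from compound 1 to compound 2 (0.05 log units; within the scatter), the expectation for compound 4 is a similarly small step: its estimated result is a 1.1-fold higher number from compound 3 to compound 4 (0.04 log units; within the scatter). On that basis compound 4 is expected to give about 1000 nM in this assay, with an estimated range from 400 nM to 2500 nM.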

Compound 4, half-maximal inhibitory concentration: 1300 nM
Compound 4: middle estimate off by 1.3-fold (0.11 log units), on the low side; the range from low to high includes it.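

In this assay, chloro in place of methoxy on the core of compound 3 gives a 1.4-fold higher number from compound 3 to compound 4 (0.15 log units; within the scatter), so this oxime pair, like the ketone pair, shows no separation beyond the scatter. The step carries from the core of compound 1 to the core of compound 3 with no difference that the method can resolve: the same change on two cores in this assay, a 1.1-fold higher number (0.05 log units; within the scatter) from compound 1 to compound 2 and a 1.4-fold higher number (0.15 log units; within the scatter) from compound 3 to compound 4, 1.3-fold (0.10 log units) apart, within the scatter of two such steps This shows that in these two pairs, 4-methoxyphenyl to 4-chlorophenyl leaves the result within the scatter on both cores, but it does not show that the two groups are equivalent in general, that the same would hold on a third core or in another assay, or why the step stays this small.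

The compounds shown leave open whether other groups at the same place, such as an amine, a carboxylic acid or a fluoro group, would also stay within the scatter of methoxy and chloro, and whether any such step would carry from one core to the other. They also leave open what a methyl ether on the oxime oxygen, or a longer chain between the sulfur and the oxime carbon, would do in this assay.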